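Shortening the alkyne substituent in a sulfonamide series

This account rests on a few compounds, and the source may have more. Where it says the series, first, only, none or still open, it means among the compounds named here.

Measured so far:
compound 1 `CCCCCCC#Cc1ccc(S(=O)(=O)Nc2cccc(-c3csc(NC(C)=O)n3)c2)cc1` gives 40.7%
compound 2 `CC(=O)Nc1nc(-c2cccc(NS(=O)(=O)c3ccc(C#C[Si](C)(C)C)cc3)c2)cs1` gives 94.3%

In a functional assay on A-375 cells (Homo sapiens) for antiproliferative activity, read by trypan blue exclusion, with a stated time of 48 h, tested at 1 uM (a lower number here means a stronger effect, a higher number a weaker effect of the compound at the concentration tested), compound 2 gives 94.3%, the highest of the two numbers; in this assay compound 1 gives 40.7%. Within the data shown here, the single measured step, a number 53.6 percentage points higher from compound 1 to compound 2 (beyond the scatter), shows that a smaller group on the triple-bonded carbon went with a much weaker effect. Compound 3 `C#Cc1ccc(S(=O)(=O)Nc2cccc(-c3csc(NC(C)=O)n3)c2)cc1` differs from compound 2 by a hydrogen atom in place of a group of 4 heavy atoms (3 carbon, 1 silicon; no ring), on a triple-bonded carbon. Among the measured compounds shown here, only that step bears on this change, and it points toward no large shift or a further weakening. Compound 3 is therefore expected to give about 88%, with a range from 60% to 105%, an expected step of a number 6.3 percentage points lower from compound 2 to compound 3 (within the scatter).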

Compound 3, a percentage reported as activity, at one concentration (the size of the read-out at that concentration, not a potency): 59.2%
Compound 3: middle estimate off by 28.8 percentage points, on the high side; measured number below the stated range.
By their numbers in this assay, from the lowest: compound 1; then compound 3; then compound 2.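

In this assay, the hydrogen-bearing alkyne separates the two larger groups: the step is a number 35.1 percentage points lower from compound 2 to compound 3 (beyond the scatter), and the step is a number 18.5 percentage points higher from compound 1 to compound 3 (beyond the scatter). The read-out at this position therefore does not follow heavy-atom count alone among these three compounds, with compound 2 going against any steady trend with group size. No measured evidence accounts for this order.

Open, from the compounds shown here alone, is how a longer chain than hexyl, or a phenyl ring, on the triple-bonded carbon would compare. Also open, going by these compounds, is whether an amine at the end of the hexyl chain would alter the read-out.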